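The source may hold more compounds than are shown below. What is called first, only, known or untested is meant among the compounds shown, and "the series" means these compounds.

Working notes, solubility series.

Compound 1 `O=C(Cn1ccnc1)N1CCC(NS(=O)(=O)c2cc(S(=O)(=O)c3ccccc3)ccc2C(F)(F)F)CC1` gives 100000 nM in a physicochemical assay for solubility; on this read-out higher numbers stand for higher solubility and lower numbers for lower solubility. Compound 2 `CC(C)C(=O)N1CCC[C@H]1C(=O)N1CCC(NS(=O)(=O)c2cc(S(=O)(=O)c3ccccc3)ccc2C(F)(F)F)CC1` gives 100000 nM in this assay, and compound 3 `CN1CCC[C@H]1C(=O)N1CCC(NS(=O)(=O)c2cc(S(=O)(=O)c3ccccc3)ccc2C(F)(F)F)CC1` gives 100000 nM. The three measured steps are all flat: no change at the digits printed from compound 1 to compound 2 (within the scatter), no change at the digits printed from compound 1 to compound 3 (within the scatter) and no change at the digits printed from compound 2 to compound 3 (within the scatter). Compound 1 therefore stands level with compounds 2 and 3 at the digits shown, with compound 2 nearest and compound 3 furthest, both within the scatter.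

Compound 4 `CC(C)(C)CCN1CCC[C@H]1C(=O)N1CCC(NS(=O)(=O)c2cc(S(=O)(=O)c3ccccc3)ccc2C(F)(F)F)CC1` is not yet measured. Its difference from compound 1 is 1-(3,3-dimethylbutyl)pyrrolidin-2-yl in place of (1H-imidazol-1-yl)methyl on a carbonyl carbon. Going by the values given here, the steps that bear on it are the two that replace the same leaving group on the same carbonyl carbon, namely no change at the digits printed from compound 1 to compound 2 (within the scatter) and no change at the digits printed from compound 1 to compound 3 (within the scatter); both stayed within the scatter, and the third step of no change at the digits printed from compound 2 to compound 3 (within the scatter) did likewise. Among the compounds with values here, the entering 1-(3,3-dimethylbutyl)pyrrolidin-2-yl group appears in none of the measured steps, so the evidence is indirect. On what is measured, compound 4 is expected to show a step of a 2.0-fold lower number from compound 1 to compound 4 (0.30 log units; within the scatter), most likely within or only modestly beyond the scatter, in the downward direction if any. The estimate for compound 4 in this assay is 50000 nM, with a range from 10000 nM to 100000 nM.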

Compound 4, solubility: 12500 nM
Beside the measured number, compound 4's estimate is 4.0-fold (0.60 log units) above it, and the stated range covers the measured number.
By their numbers in this assay, from the lowest: compound 4; then compounds 1, 2 and 3 (each within the scatter of the next).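

In this assay, going by these compounds alone, this position, on a carbonyl carbon whose other neighbour is an amide-type nitrogen in a ring, no longer reads flat: 1-(3,3-dimethylbutyl)pyrrolidin-2-yl in place of (1H-imidazol-1-yl)methyl gives an 8.0-fold lower number from compound 1 to compound 4 (0.90 log units; beyond the scatter), the first step beyond the scatter. With the pyrrolidin-2-yl kept, the steps match: neopentyl in place of hydrogen gives an 8.0-fold lower number from compound 3 to compound 4 (0.90 log units; beyond the scatter), and 3,3-dimethylbutyl in place of isopropylcarbonyl gives an 8.0-fold lower number from compound 2 to compound 4 (0.90 log units; beyond the scatter), so among these compounds only the one carrying 3,3-dimethylbutyl on the amine nitrogen in a ring stands apart. No measurement available here accounts for this step.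

Going by these compounds, how an ethyl, an unbranched hexyl chain or a terminal carboxylic acid on that amine nitrogen would read in this assay remains open. Whether the step follows chain length or the branching of the chain also stays unresolved.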